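A few compounds are considered here, and "the series" means these few. Any claim that something is new, unique, unknown or untested is made for them only; others in the source may bear on it.

Measured so far in a functional assay on BGC-823 cells (Homo sapiens) for cytotoxicity, read by CCK-8 assay, with a stated time of 72 h; a lower number here means a stronger inhibitor, a higher number a weaker inhibitor:
- compound 1 `COc1ccccc1/C=c1/[nH]c(=O)/c(=C\c2ccccc2OC)[nH]c1=O`: compound 1 gives "not active" (no number reported)
- compound 2 `C=CCn1c(=O)/c(=C\c2cccc(Br)c2)[nH]c(=O)/c1=C\c1ccccc1OC`: compound 2 gives 5900 nM
- compound 3 `C=CCn1c(=O)/c(=C\c2cccc(Br)c2)[nH]c(=O)/c1=C\c1cccc(Br)c1`: compound 3 gives "not active" (no number reported)

Of the compounds shown here, three share the same core and have been tested in this assay. Within the data shown here, only compound 2 received a number; for compound 1 and compound 3 the read-out gave no number at all, so there is nothing to rank compound 2 against, and it simply stands as the one compound with a measured value.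

Compound 4 `C=CCn1c(=O)/c(=C\c2ccccc2C(F)(F)F)[nH]c(=O)/c1=C\c1ccccc1OC` has not been tested. It differs from compound 2 in one place: 2-(trifluoromethyl)phenyl in place of 3-bromophenyl on a double-bonded chain carbon bound to an aromatic carbon. Among the measured compounds shown here, no pair of measured compounds shows what such a change does on this core, so there is no step to lean on. With compound 2 as the only anchor, and two close relatives that returned no number, the step is expected to stay within the scatter or to lean towards a weaker result rather than a stronger one; the chance that compound 4 also returns no number is real. The expected step from compound 2 to compound 4 in this assay is a 1.5-fold higher number from compound 2 to compound 4 (0.18 log units; within the scatter). Compound 4 is therefore estimated at 9000 nM, with a range from 2500 nM to 35000 nM.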

Compound 4, half-maximal inhibitory concentration: 5100 nM
The estimate for compound 4 lay 1.8-fold (0.25 log units) above the measured number; low and high end bracket the measured number.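

In this assay, exchanging the 3-bromophenyl group for a 2-(trifluoromethyl)phenyl group gives a 1.2-fold lower number from compound 2 to compound 4 (0.06 log units; within the scatter), so the two compounds cannot be told apart in this read-out. Among these compounds, this is the first measured step at this position, and it shows that the number survives an exchange of one aromatic group for another, even though the entering group counts 10 heavy atoms against 7 for the leaving one. No measurement is available that could explain this outcome.

The compounds shown leave open whether a phenyl group carrying an amine or a carboxylic acid at this position would also give a number, or whether a longer chain in place of the aromatic group would do so. They also leave open how much of the activity depends on the other aromatic group, since compound 3 gives "not active" (no number reported) and no step can be read from a result without a number.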